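A Fluoro for Hydrogen Exchange on a Stable Scaffold

The source may report more compounds than this note shows. Statements on the series, on what has been measured and on what is new or still open speak of the compounds shown alone.

Of the compounds shown here, two have been measured in an ADME assay on microsomes from intestine (Rattus norvegicus) for metabolic stability, with NADPH named in the record, with a stated time of 60 min, in the absence of a further agent; on this read-out higher numbers stand for a more stable compound and lower numbers for a less stable compound. Compound 1, with the structure `CCn1cc(-c2cc3c(-c4cccc(N5CCN(C)CC5)n4)n[nH]c3cn2)cn1`, gives 82% in this assay. Compound 2, with the structure `Cc1cncc(-c2ccc3cnn(-c4cccc(N5CCCNCC5)n4)c3c2)n1`, gives 91% in this assay, the higher of the two numbers, although its gap to compound 1 lies within the usual scatter of such measurements, so the two cannot be ranked. Compound 3, with the structure `Cc1cncc(-c2cc(F)c3cnn(-c4cccc(N5CCCNCC5)n4)c3c2)n1`, has not yet been measured in this assay. It differs from compound 2 in one place: fluoro in place of hydrogen on an aromatic carbon. Within the data shown here, no pair of measured compounds shows what this exchange does on this read-out. Since compound 2 already gives 91% in this assay, little room remains upward, and the exchange is expected to produce a step of a number 2 percentage points lower from compound 2 to compound 3 (within the scatter), not beyond the scatter. Compound 3 is accordingly expected to show about 89% in this assay, within a range from 76% to 98%.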

Compound 3, percent of the compound remaining: 108%
Compound 3: the middle estimate sits 19 percentage points below what was measured; the whole stated range lies below it.
By their numbers in this assay, from the lowest: compounds 1 and 2 (each within the scatter of the next); then compound 3.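

In this assay, fluoro in place of hydrogen on an aromatic carbon, ortho to a fused ring and meta to a 6-methylpyrazin-2-yl group, gives a number 17 percentage points higher from compound 2 to compound 3 (beyond the scatter). The earlier compounds shown here differ in more than one place and could not show this; the step shows that this position accepts the exchange with no loss on this read-out, even from a starting number near the top of the scale. Compound 3 gives 108% as a reading past the whole of the compound, so it marks no measurable loss and should not be read as an exact size of gain.

Nothing given here says why the number rises. As far as these compounds go, whether chloro or methoxy on the same carbon would behave as fluoro does remains open, as does whether the exchange would carry over to the core of compound 1.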